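The source may hold more compounds than are shown below. What is called first, only, known or untested is meant among the compounds shown, and "the series" means these compounds.

The measured compounds:
Compound 1 `Cc1cn(C2CCN(Cc3cccc(Oc4cc(C(F)(F)F)cc(C(F)(F)F)c4)c3)CC2)c(=O)[nH]c1=O`: "not determined" (no result reported)
Compound 2 `Cc1cn(C2CCN(Cc3cccc(Oc4cc(F)cc(F)c4)c3)CC2)c(=O)[nH]c1=O`: > 64000 nM
Compound 3 `Cc1cn(C2CCN(Cc3cc(Oc4cc(Cl)cc(Cl)c4)ccn3)CC2)c(=O)[nH]c1=O`: "not determined" (no result reported)

The three compounds share a core and differ in the group carried on an oxygen on an aromatic ring. In an ADME assay on MRC5 cells (Homo sapiens) for cytotoxicity, read by fluorescence and resazurin assay, with a stated time of 3 days (a lower number here means a stronger inhibitor, a higher number a weaker inhibitor), compound 1 has no recorded result, and compound 3 likewise has none. Compound 2 alone carries an entry, and that entry is a limit rather than a number: in this assay compound 2 gives > 64000 nM, which is the limit of > 64000 nM in this assay, at which 1 of the 3 values shown sits. Compound 2 therefore stands at the edge of what the assay can report, with no single number to place it more precisely, and of the three entries shown it is the only one with any value at all.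

The step to compound 4 `Cc1cn(C2CCN(Cc3cccc(Oc4cccc(Cl)c4)c3)CC2)c(=O)[nH]c1=O` is 3-chlorophenyl in place of 3,5-difluorophenyl on an oxygen on an aromatic ring. Within the data shown here, no step between two measured compounds is available to show what such a change does in this assay. Starting from a limit, the expectation is for no step beyond the scatter in this assay. Compound 4 is expected at 70000 nM, with a range from 30000 nM to 200000 nM. The expected step is a step that the limit leaves unreadable from compound 2 to compound 4, most probably reported again only as a limit.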

Compound 4, half-maximal inhibitory concentration: 21000 nM
Beside the measured number, compound 4's estimate is 3.3-fold (0.52 log units) above it; measured number below the stated range.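

In this assay, swapping the group on this oxygen produces a clear shift, with 3-chlorophenyl in place of 3,5-difluorophenyl giving an at least 3.0-fold lower number from compound 2 to compound 4 (0.48 log units; beyond the scatter). The earlier compounds shown here could not show this, since the only entry among them was a limit, whereas compound 4 now gives the series a single number and shows that the group at this place can bring the reading within what the assay reports. Compound 2 remains a limit, so the step fixes only a minimum size and the full extent of the change stays unknown: the limit of > 64000 nM in this assay, at which 1 of the 4 values shown sits.

The change removes two fluorines and brings in one chlorine, so the compounds shown cannot separate the effect of the chlorine from that of losing a second group on the ring, and steps to compound 1 and compound 3 cannot be read. As far as these compounds go, how a plain phenyl, or a phenyl carrying an amine or a carboxylic acid, would read on this oxygen remains open.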